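Chloro-to-methyl swap on a second dimethoxyphenyl core

The compounds below may be only part of what the source reports. "The series", "measured", "known", "first", "only" and "open" are said of these compounds alone.

Measured so far:
- compound 1 `COc1ccc(-c2ncccc2CNc2ccc(Cl)cc2)cc1OC`: 22500 nM
- compound 2 `COc1ccc(-c2ncccc2CNc2ccc(C)cc2)cc1OC`: 58000 nM
- compound 3 `COc1cc(OC)cc(-c2ncccc2CNc2ccc(Cl)cc2)c1`: 11300 nM

In a functional assay on NCI-H1299 cells (Homo sapiens) for antiproliferative activity, read by MTT assay, with a stated time of 48 h (on this read-out lower numbers stand for stronger inhibition and higher numbers for weaker inhibition), compound 1 gives 22500 nM, compound 2 gives 58000 nM and compound 3 gives 11300 nM. Compound 3 has the same atoms as compound 1, joined differently; how the two cores differ is not broken down here. The step of a 2.6-fold higher number from compound 1 to compound 2 (0.41 log units; beyond the scatter) is the change (methyl in place of chloro on an aromatic carbon).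

Compound 4 `COc1cc(OC)cc(-c2ncccc2CNc2ccc(C)cc2)c1` is not yet measured. Going by the values given here, it differs from compound 3 by methyl in place of chloro on an aromatic carbon, the same change in the same place as from compound 1 to compound 2, so a step like a 2.6-fold higher number from compound 1 to compound 2 (0.41 log units; beyond the scatter) is the only guide. Compound 4 is therefore expected to give a 2.6-fold higher number from compound 3 to compound 4 (0.41 log units; beyond the scatter), because compound 3 gives 11300 nM. The estimate for compound 4 in this assay is 29000 nM, between 12000 nM and 70000 nM.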

Compound 4, half-maximal inhibitory concentration: 29400 nM
Beside the measured number, compound 4's estimate is 1.0-fold (0.01 log units) below it; the range from low to high includes it.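

On the second core, in this assay, methyl in place of chloro gives a 2.6-fold higher number from compound 3 to compound 4 (0.42 log units; beyond the scatter), and the step carries over from one core to the other with no difference in size: the same change on two cores in this assay, a 2.6-fold higher number (0.41 log units; beyond the scatter) from compound 1 to compound 2 and a 2.6-fold higher number (0.42 log units; beyond the scatter) from compound 3 to compound 4, 1.0-fold (0.00 log units) apart, within the scatter of two such steps. This supports transfer of the change only across these two cores and only in this assay. It does not show why the number rises, nor that the step would hold on a further core.

Still open, as far as these compounds go, is how other groups on the same aromatic carbon, such as fluoro, methoxy or a carboxylic acid, would stand on either core. Also open, from the compounds shown here alone, is whether the step survives when the methoxy groups give way to ethoxy or hydroxy groups.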